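What a Second Hydroxy May Do to Compound 3

The compounds below may be only part of what the source reports. "The series", "measured", "known", "first", "only" and "open" are said of these compounds alone.

In a functional assay on HepG2 cells (Homo sapiens) for antiproliferative activity, read by MTT assay, with a stated time of 72 h (on this read-out higher numbers stand for weaker inhibition and lower numbers for stronger inhibition), compound 1 `O=C(N/N=C/c1ccccc1)Nc1ccc(Oc2ccnc3[nH]ccc23)c(F)c1` gives 640 nM and compound 2 `O=C(N/N=C/c1cccc(Br)c1)Nc1ccc(Oc2ccnc3[nH]ccc23)c(F)c1` gives 660 nM. The bromo group leaves the number where it was, with a 1.0-fold higher number from compound 1 to compound 2 (0.01 log units; within the scatter). Compound 3 `O=C(N/N=C/c1ccc(O)cc1)Nc1ccc(Oc2ccnc3[nH]ccc23)c(F)c1` gives 1950 nM, the highest of the three numbers and so the weakest inhibition of the set. It lies beyond the scatter from both neighbours, with a 3.0-fold higher number from compound 1 to compound 3 (0.48 log units; beyond the scatter) and a 3.0-fold higher number from compound 2 to compound 3 (0.47 log units; beyond the scatter).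

Compound 4 `O=C(N/N=C/c1ccc(O)cc1O)Nc1ccc(Oc2ccnc3[nH]ccc23)c(F)c1` has not yet been measured. It has hydroxy in place of hydrogen on an aromatic carbon, which turns 4-hydroxyphenyl into 2,4-dihydroxyphenyl: hydroxy in place of hydrogen on an aromatic carbon. The new group stands ortho to a large group and meta to a hydroxy group. For the measured compounds named here, the closest precedent is the only measured step that adds a hydroxy, a 3.0-fold higher number from compound 1 to compound 3 (0.48 log units; beyond the scatter), which was modest and went toward weaker inhibition. Going by the values given here, that is a single example, and no measured compound carries a group in the new place or bears two hydroxy groups. The expected change is therefore small and in the same direction, possibly not clearing the scatter: a 1.5-fold higher number from compound 3 to compound 4 (0.19 log units; within the scatter). For compound 4 the estimated value is 3000 nM, with an expected range from 1000 nM to 9000 nM.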

Compound 4, half-maximal inhibitory concentration: 4550 nM
Compound 4: the middle estimate sits 1.5-fold (0.18 log units) below what was measured; measured number inside the range.
By their numbers in this assay, from the lowest: compounds 1 and 2 (each within the scatter of the next); then compound 3; then compound 4.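

In this assay, the second hydroxy, ortho to a large group and meta to a hydroxy group, goes the same way as the first, with a 2.3-fold higher number from compound 3 to compound 4 (0.37 log units; beyond the scatter) and again toward weaker inhibition, so a hydroxy added at this new place did not restore what the first one lost. Measured against the plain phenyl and the 3-bromophenyl groups, the 2,4-dihydroxyphenyl group gives a 7.1-fold higher number from compound 1 to compound 4 (0.85 log units; beyond the scatter) and a 6.9-fold higher number from compound 2 to compound 4 (0.84 log units; beyond the scatter) and these are the largest steps in the set, which leaves compound 4 beyond the scatter from all three other compounds and the weakest inhibitor of the four. No measurement here accounts for either hydroxy step.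

The compounds shown leave open whether the loss belongs to this place on the ring or to the two hydroxy groups together, as no compound carries a hydroxy here without the other one. They also leave open how a methoxy or an amine would read at this same place, and so whether the step is particular to hydroxy.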